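The source may report more compounds than this note shows. Statements on the series, on what has been measured and on what is new or still open speak of the compounds shown alone.

Compound 1 `N#Cc1cccnc1N1CCN([C@@H]2CN[C@H](C(=O)N3CCSC3)C2)CC1` stands lowest of the three numbers in an assay on a cell-free system (plasma) for inhibition of Dipeptidyl peptidase 4 (Rattus norvegicus), read by fluorescence (a higher number here means a weaker inhibitor, a lower number a stronger inhibitor), where compound 1 gives 1.2 nM. Compound 2 `O=C([C@@H]1C[C@H](N2CCN(c3ccccn3)CC2)CN1)N1CCSC1` gives 3.5 nM, and compound 3 `N#Cc1ccnc(N2CCN([C@@H]3CN[C@H](C(=O)N4CCSC4)C3)CC2)c1` gives 1.9 nM. Compound 4 `O=C([C@@H]1C[C@H](N2CCN(c3ccc(Cl)cn3)CC2)CN1)N1CCSC1` differs from compound 1 in one place: 5-chloropyridin-2-yl in place of 3-cyanopyridin-2-yl on an amine nitrogen in a ring. Among the compounds with values here, two measured steps bear on this change. Taking the cyano away gave a 2.9-fold higher number from compound 1 to compound 2 (0.46 log units; beyond the scatter), whereas moving it to another carbon gave a 1.6-fold higher number from compound 1 to compound 3 (0.20 log units; within the scatter). Because the loss of the cyano gave a 2.9-fold higher number from compound 1 to compound 2 (0.46 log units; beyond the scatter), a modest weakening is expected for compound 4, about a 2.5-fold higher number from compound 1 to compound 4 (0.40 log units; beyond the scatter). Compound 4 is therefore estimated in this assay at 3 nM, with a likely range from 1 nM to 9 nM.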

Compound 4, half-maximal inhibitory concentration: 3.1 nM
Compound 4: middle estimate off by 1.0-fold (0.01 log units), on the low side; the measured number falls inside the stated range.
By their numbers in this assay, from the lowest: compounds 1, 3, 4 and 2 (each within the scatter of the next, the first and the last beyond it).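

In this assay, 5-chloropyridin-2-yl in place of 3-cyanopyridin-2-yl gave a 2.6-fold higher number from compound 1 to compound 4 (0.41 log units; beyond the scatter), so a ring with chloro and no cyano does not match compound 1 at this place. Chloro in place of hydrogen gave a 1.1-fold lower number from compound 2 to compound 4 (0.05 log units; within the scatter), leaving compound 4 unseparated from compound 2. Against the 4-cyanopyridin-2-yl group, the change gave a 1.6-fold higher number from compound 3 to compound 4 (0.21 log units; within the scatter), so compound 4 is not separated from compound 3 either. From the compounds shown here alone, whether an amine or a methoxy group on the pyridine ring would give a number in this same narrow span stays open. No measurement shown here explains any of these steps.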